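From Sulfamoyl to Trifluoromethyl on a Shared Core

A few compounds are considered here, and "the series" means these few. Any claim that something is new, unique, unknown or untested is made for them only; others in the source may bear on it.

Compound 1 `NS(=O)(=O)c1ccc(-c2nc3cc([N+](=O)[O-])ccc3[nH]2)cc1` was tested in a functional assay for antagonist activity at Neuropeptides B/W receptor type 1 (Homo sapiens), read by cAMP accumulation; on this read-out higher numbers stand for weaker inhibition and lower numbers for stronger inhibition. Compound 1 reaches only the limit of the assay, > 31600 nM, which is a boundary and not a measured number. Two further compounds on the same core do give numbers: in this assay compound 2 `O=[N+]([O-])c1ccc2[nH]c(-c3ccccc3N3CCCC3)nc2c1` gives 6770 nM, and compound 3 `O=[N+]([O-])c1ccc2[nH]c(-c3ccc(Cl)cc3Br)nc2c1` gives 1760 nM. Compound 4 `O=[N+]([O-])c1ccc2[nH]c(-c3ccc(C(F)(F)F)cc3)nc2c1` differs from compound 1 by trifluoromethyl in place of sulfamoyl on an aromatic carbon, in words trifluoromethyl in place of sulfamoyl on an aromatic carbon. For the measured compounds named here, no measured pair shows this change, so the size of the step is open; a move from the limit toward a measurable value is expected. Compound 4 is therefore expected to give about 12000 nM, estimated between 3500 nM and 31600 nM. This expectation amounts to a step of an at least 2.6-fold lower number from compound 1 to compound 4 (0.42 log units; beyond the scatter).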

Compound 4, half-maximal inhibitory concentration: > 31600 nM
Compound 4 was reported as a limit; the forecaster's own chance of this, stated with the estimate: 35%; at least 2.6-fold (0.42 log units) between middle value and limit.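

For the compounds shown here, compound 1 and compound 4 both sit at a limit rather than at a measured number, so no step between them can be read: the limit of > 31600 nM in this assay, at which 2 of the 4 values shown sit. The compounds shown leave open whether trifluoromethyl in place of sulfamoyl changes inhibition at all, and in which direction.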